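This account rests on a few compounds, and the source may have more. Where it says the series, first, only, none or still open, it means among the compounds named here.

Three compounds sharing one core were tested in a functional assay on HEK293 cells for negative allosteric modulation of metabotropic glutamate receptor 5 (Homo sapiens), read by calcium flux, with a stated time of 20 min; on this read-out higher numbers stand for weaker inhibition and lower numbers for stronger inhibition. Compound 1 `O=C(c1ccccc1)N1CCn2nc(-c3cccnc3)cc2C1`, bearing pyridin-3-yl, gives only a limit in this assay, > 10000 nM (the limit of > 10000 nM in this assay, at which 1 of the 3 values shown sits). Compound 2 `Cc1ccc(-c2cc3n(n2)CCN(C(=O)c2ccccc2)C3)nc1`, carrying 5-methylpyridin-2-yl, gives 244 nM. Compound 3 `Cc1cccc(-c2cc3n(n2)CCN(C(=O)c2ccccc2)C3)n1`, carrying 6-methylpyridin-2-yl, gives 568 nM, the highest of the two numbers; its nearest neighbour is compound 2, and a 2.3-fold higher number from compound 2 to compound 3 (0.37 log units; beyond the scatter) is modest, while an at least 17-fold lower number from compound 1 to compound 3 (1.24 log units; beyond the scatter) is large.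

Compound 4 `O=C(c1ccccc1)N1CCn2nc(-c3ccc(F)cn3)cc2C1` is not yet measured. It differs from compound 3 in one place: 5-fluoropyridin-2-yl in place of 6-methylpyridin-2-yl on an aromatic carbon. Two kinds of measured step bear on this change. Replacing pyridin-3-yl with a methyl-bearing pyridin-2-yl gave an at least 40-fold lower number from compound 1 to compound 2 (1.61 log units; beyond the scatter) and an at least 17-fold lower number from compound 1 to compound 3 (1.24 log units; beyond the scatter), and moving the methyl within that ring gave a 2.3-fold higher number from compound 2 to compound 3 (0.37 log units; beyond the scatter). The 5-fluoropyridin-2-yl of compound 4 resembles the 5-methylpyridin-2-yl of compound 2 more than the 6-methylpyridin-2-yl of compound 3, so a modest downward step is expected, a 1.9-fold lower number from compound 3 to compound 4 (0.28 log units; within the scatter). The estimate for compound 4 is 300 nM, with a range from 100 nM to 1000 nM.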

Compound 4, half-maximal inhibitory concentration: 164 nM
The estimate for compound 4 lay 1.8-fold (0.26 log units) above the measured number; the measured number falls inside the stated range.
By their numbers in this assay, from the lowest: compounds 4 and 2 (each within the scatter of the next); then compound 3. At a limit, above all of these: compound 1.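

Fluoro and methyl cannot be told apart on this ring: fluoro in place of methyl gives a 1.5-fold lower number from compound 2 to compound 4 (0.17 log units; within the scatter). The change from the 6-methylpyridin-2-yl of the earlier compound gives a 3.5-fold lower number from compound 3 to compound 4 (0.54 log units; beyond the scatter), but both the group and its place on the ring change in this step, so it cannot show which of the two matters. The 5-fluoropyridin-2-yl in place of pyridin-3-yl gives an at least 60-fold lower number from compound 1 to compound 4 (1.78 log units; beyond the scatter), and compound 1 is a limit: the limit of > 10000 nM in this assay, at which 1 of the 4 values shown sits.

Still open, as far as these compounds go, is how a pyridin-2-yl ring with no added group would read, and how chlorine, a methoxy group or a nitrile would compare with fluoro and methyl on that ring. A 6-fluoropyridin-2-yl would separate the effect of the group from that of its place.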